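A New Aryl Group at the Limit of the Assay

A few compounds are considered here, and "the series" means these few. Any claim that something is new, unique, unknown or untested is made for them only; others in the source may bear on it.

In a physicochemical assay for solubility, in phosphate buffer, measured as kinetic solubility, at pH 7.4 (on this read-out higher numbers stand for higher solubility and lower numbers for lower solubility), compound 2 `Cc1ccc(-c2nc(CN3CCC(C(=O)NCCCN4C[C@H](C)C[C@H](C)C4)CC3)c(C)o2)cc1` gives > 69 ug/mL, which is a limit and not a number. Among the compounds with values here, its one measured neighbour is compound 1 `Cc1oc(-c2c(F)cccc2F)nc1CN1CCC(C(=O)NCCCN2C[C@H](C)C[C@H](C)C2)CC1`. In this assay compound 1 gives > 72 ug/mL, which is also a limit. Compound 3 `COc1cccc(Cl)c1-c1nc(CN2CCC(C(=O)NCCCN3C[C@H](C)C[C@H](C)C3)CC2)c(C)o1` has not yet been measured. It carries 2-chloro-6-methoxyphenyl in place of 4-methylphenyl on an aromatic carbon of a five-membered aromatic ring with 1 nitrogen and 1 oxygen, next to the ring nitrogen and next to the ring oxygen: 2-chloro-6-methoxyphenyl in place of 4-methylphenyl on an aromatic carbon. Within the data shown here, the only measured step at this place is a step that the two limits leave unreadable from compound 1 to compound 2, which put 4-methylphenyl in place of 2,6-difluorophenyl on an aromatic carbon. The size of that step cannot be read, and it sets no direction. Among the measured compounds shown here, with a step that the two limits leave unreadable from compound 1 to compound 2 as the only guide, no step beyond the scatter is expected in this assay, and another limit is the likeliest report. The expected change is a step that the limit leaves unreadable from compound 2 to compound 3. Compound 3 is estimated at 75 ug/mL, with an expected range of 40 ug/mL to 90 ug/mL.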

Compound 3, solubility: > 76 ug/mL
Compound 3 ended at the assay's limit; the forecaster's own chance of this, stated with the estimate: 75%; middle value at least 1.0-fold (0.00 log units) away from the limit.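

In this assay compound 3 gives > 76 ug/mL, which is a limit of the assay and not a number. Within the data shown here, compound 1 and compound 2 also report limits, and no step among the three compounds can be read. The compounds shown leave open whether 2,6-difluorophenyl, 4-methylphenyl and 2-chloro-6-methoxyphenyl differ at all in this assay.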